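The compounds below may be only part of what the source reports. "The series", "measured", "known", "first", "only" and "open" are said of these compounds alone.

Compound 1 `N[C@H]1CC[C@H](Oc2ccc([C@H]3CC[C@]4(CC3)OOC3(O4)C4CC5CC(C4)CC3C5)cc2)CC1`: < 7 mL.min-1.g-1, a limit
Compound 2 `CC(C)(N)CCOc1ccc([C@H]2CC[C@]3(CC2)OOC2(O3)C3CC4CC(C3)CC2C4)cc1`: < 7 mL.min-1.g-1, a limit
Compound 3 `NCCCCOc1ccc([C@H]2CC[C@]3(CC2)OOC2(O3)C3CC4CC(C3)CC2C4)cc1`: < 7 mL.min-1.g-1, a limit

In an ADME assay on microsomes from liver (Homo sapiens) for metabolic stability, read by LC-MS, tested at 1 uM (a higher number here means faster removal of the compound, a lower number slower removal), compound 3 has no number, only a limit, and the series shares (the limit of < 7 mL.min-1.g-1 in this assay, at which 3 of the 3 values shown sit).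

Compound 4 `CC1(C)CC(O)(COc2ccc([C@H]3CC[C@]4(CC3)OOC3(O4)C4CC5CC(C4)CC3C5)cc2)CC(C)(C)N1` carries 4-hydroxy-2,2,6,6-tetramethylpiperidin-4-yl in place of 3-aminopropyl on a saturated chain carbon bound to an oxygen on an aromatic ring.

The closest measured changes alter the same side chain: a step that the two limits leave unreadable from compound 1 to compound 2, a step that the two limits leave unreadable from compound 1 to compound 3 and a step that the two limits leave unreadable from compound 2 to compound 3. None gives a size. No step beyond the scatter is therefore expected in this assay because of the limit of < 7 mL.min-1.g-1 in this assay, at which 3 of the 3 values shown sit.

The expected step is a step that the limit leaves unreadable from compound 3 to compound 4.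

Compound 4 is estimated at 6 mL.min-1.g-1, with an expected range of 3 mL.min-1.g-1 to 15 mL.min-1.g-1.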

Compound 4, intrinsic clearance in microsomes in the liver assay: 14 mL.min-1.g-1
For compound 4 the middle estimate is 2.3-fold (0.37 log units) below the measured one; the range from low to high includes it.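

In the liver assay compound 4 gives 14 mL.min-1.g-1, and the change at this position gives an at least 2.0-fold higher number from compound 3 to compound 4 (0.30 log units; that floor lies within the scatter), an at least 2.0-fold higher number from compound 2 to compound 4 (0.30 log units; that floor lies within the scatter) and an at least 2.0-fold higher number from compound 1 to compound 4 (0.30 log units; that floor lies within the scatter), and each of these floors lies within the scatter. Compound 4 is the only compound shown here with a number rather than a limit: the limit of < 7 mL.min-1.g-1 in the liver assay, at which 3 of the 4 values shown sit. In a physicochemical assay for solubility, read by nephelometry, measured as kinetic solubility, with a stated time of 30 min (a higher number here means a more soluble compound, a lower number a less soluble compound), compound 3 gives 50 ug/mL. In the physicochemical assay compound 4 gives > 100 ug/mL, which is a limit. In the physicochemical assay the same change gives an at least 2.0-fold higher number from compound 3 to compound 4 (0.30 log units; that floor lies within the scatter), again with a floor within the scatter.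

Whether the ring, the hydroxyl or the methyl groups of the 4-hydroxy-2,2,6,6-tetramethylpiperidin-4-yl group account for the step remains open. Also open, as far as these compounds go, is what a plain piperidine or a morpholine would give on this saturated chain carbon.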